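A few compounds are considered here, and "the series" means these few. Any claim that something is new, unique, unknown or untested is made for them only; others in the source may bear on it.

Of the compounds shown here, three built on one shared core have been measured in a functional assay on HCT-116 cells (Homo sapiens) for cytotoxicity, read by MTT assay, with a stated time of 48 h; on this read-out lower numbers stand for stronger inhibition and higher numbers for weaker inhibition. Compound 1 `O=C(/C=C/c1ccc2c(c1)B(O)OC2)c1ccc(-c2ccccc2)cc1` gives 9500 nM, compound 3 `Cc1ccc(C(=O)/C=C/c2ccc3c(c2)B(O)OC3)cc1` gives 10500 nM, and compound 2 `O=C(/C=C/c1ccc2c(c1)B(O)OC2)c1ccco1` gives 24100 nM, which is the highest of the three numbers. Putting methyl in place of phenyl on an aromatic carbon produced a 1.1-fold higher number from compound 1 to compound 3 (0.04 log units; within the scatter), so that change hardly mattered. Putting 4-methylphenyl in place of furan-2-yl on a carbonyl carbon produced a 2.3-fold lower number from compound 2 to compound 3 (0.36 log units; beyond the scatter), a modest drop beyond the scatter.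

Compound 4 `O=C(/C=C/c1ccc2c(c1)B(O)OC2)c1ccccc1F` has not yet been measured. It differs from compound 2 as follows: 2-fluorophenyl in place of furan-2-yl on a carbonyl carbon. The measured step from compound 2 to compound 3 bears most directly on this change, since both exchange furan-2-yl for a six-membered aromatic ring of carbon only on the carbonyl carbon; compound 1 shows the same kind of lower number. A drop of comparable size is therefore expected, giving an estimated step of a 2.2-fold lower number from compound 2 to compound 4 (0.34 log units; beyond the scatter). Compound 4 is expected to give about 11000 nM in this assay, with a likely range from 5500 nM to 22000 nM.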

Compound 4, half-maximal inhibitory concentration: 4200 nM
Compound 4: the middle estimate sits 2.6-fold (0.42 log units) above what was measured; measured number outside the range, below it.
By their numbers in this assay, from the lowest: compound 4; then compounds 1 and 3 (each within the scatter of the next); then compound 2.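

The ring on the carbonyl carbon matters more than compounds 2 and 3 alone suggested: 2-fluorophenyl in place of furan-2-yl gives a 5.7-fold lower number from compound 2 to compound 4 (0.76 log units; beyond the scatter). Moving from a five-membered to a six-membered aromatic ring does not by itself set the number, since 2-fluorophenyl in place of 4-methylphenyl still gives a 2.5-fold lower number from compound 3 to compound 4 (0.40 log units; beyond the scatter). Among these compounds, then, what the six-membered ring carries also counts, and lower numbers here mean stronger inhibition.

No measured information shown here accounts for these differences. Still open, going by these compounds, is whether fluorine itself matters or whether another group on the same ring, such as a chlorine atom, an amine or a carboxylic acid, would give a similar number.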